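Amino for trifluoromethyl on the benzylamine arm

The compounds below may be only part of what the source reports. "The series", "measured", "known", "first", "only" and "open" are said of these compounds alone.

Three compounds of the series have numbers in an assay for inhibition of Indoleamine 2,3-dioxygenase 1 (Homo sapiens), with stated times of 10 min and 60 min, tested at 100 uM; a higher number here means a stronger effect of the compound at the concentration tested, a lower number a weaker effect. Compound 1 `O=[N+]([O-])c1cc(OCc2ccccc2)ccc1CNc1cc(C(F)(F)F)cc2[nH]ncc12` gives 20%. Compound 2 `FC(F)(F)c1cccc(CNc2cc(C(F)(F)F)cc3[nH]ncc23)c1` gives 49%. Compound 3 `O=[N+]([O-])c1ccc(O)cc1CNc1cc(Br)cc2[nH]ncc12` gives 98%. Compound 2 thus stands second of the three: its number lies above that of compound 1 by a gap beyond the scatter, and below that of compound 3 by a larger gap, also beyond the scatter. For the measured compounds named here, no pair among the measured compounds differs in one place only, so no single step can be read from them.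

Compound 4 `Nc1cccc(CNc2cc(C(F)(F)F)cc3[nH]ncc23)c1` is not yet measured in this assay. It differs from compound 2 in one place: amino in place of trifluoromethyl on an aromatic carbon, on an aromatic carbon of a six-membered aromatic ring of carbon only, meta to a large group. Going by the values given here, no measured pair shows the effect of this exchange, so the direction rests on nothing firmer than the spread of the three numbers. A moderate step is expected, more likely downward than upward, a number 9 percentage points lower from compound 2 to compound 4 (within the scatter). Compound 4 is therefore estimated at 40%, with a range from 10% to 75%.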

Compound 4, a percentage reported as inhibition, at one concentration (the size of the read-out at that concentration, not a potency): 55%
The estimate for compound 4 lay 15 percentage points below the measured number, and the stated range covers the measured number.
By their numbers in this assay, from the lowest: compound 1; then compounds 2 and 4 (each within the scatter of the next); then compound 3.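

For the compounds shown here, this is the first step that can be read in one place: in this assay, amino in place of trifluoromethyl on an aromatic carbon gives a number 6 percentage points higher from compound 2 to compound 4 (within the scatter). At this position, meta to a large group, a trifluoromethyl of 4 heavy atoms with no hydrogen-bond donor and an amino of 1 heavy atom with 1 hydrogen-bond donor are not separated by this read-out, although it is taken at one concentration and is not a potency. Nothing at hand bears on the reason for this result.

Still open, going by these compounds, is whether a carboxylic acid, a nitrile or a methoxy group at the same position would also leave the number within the scatter of these two compounds. Also open, on these data alone, is whether the same exchange would give a similar step on an arm that also carries a nitro group.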